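The source may hold more compounds than are shown below. What is called first, only, known or untested is meant among the compounds shown, and "the series" means these compounds.

Three compounds have been measured in a functional assay on MCF7 cells (Homo sapiens) for inhibition; a higher number here means a weaker inhibitor, a lower number a stronger inhibitor:

Compound 1, `CCC(C)C1NC(=O)N(C2CCCC2)C1=O`: 67400 nM
Compound 2, `CC(C)C1NC(=O)N(C2CCCC2)C1=O`: a limit only, > 100000 nM
Compound 3, `CC(C)C(NC(=O)n1nnc2ccccc21)C(=O)NC1CCCC1`: 79300 nM

Compound 2 and compound 3 differ in more than one place, so the difference between their two cores is not broken down here. In this assay compound 1 and compound 3 give numbers that lie within the scatter of each other. Within the first core, the change methyl in place of hydrogen on a saturated chain carbon, two bonds along the chain from a saturated ring carbon made a step of an at least 1.4-fold lower number from compound 2 to compound 1 (0.17 log units; that floor lies within the scatter), and its size is bounded only by the limit of > 100000 nM in this assay, at which 1 of the 3 values shown sits.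

Compound 4, `CCC(C)C(NC(=O)n1nnc2ccccc21)C(=O)NC1CCCC1`, carries the same kind of change on the second core: methyl in place of hydrogen on a saturated chain carbon, three bonds along the chain from an amide-type nitrogen and a carbonyl carbon. The surroundings are not identical, since the first change sits two bonds along the chain from a saturated ring carbon while the second sits three bonds along the chain from an amide-type nitrogen and a carbonyl carbon. For compound 4 a step of a 1.4-fold lower number from compound 3 to compound 4 (0.16 log units; within the scatter) is expected, resting on the step of an at least 1.4-fold lower number from compound 2 to compound 1 (0.17 log units; that floor lies within the scatter) measured for the same kind of change. Compound 4 is therefore estimated at 55000 nM, between 20000 nM and 150000 nM.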

Compound 4, half-maximal inhibitory concentration: 63700 nM
Compound 4: the middle estimate sits 1.2-fold (0.06 log units) below what was measured; the measured number falls inside the stated range.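

In this assay, the change from isopropyl to sec-butyl on the second core gave a 1.2-fold lower number from compound 3 to compound 4 (0.10 log units; within the scatter), so on that core this added methyl leaves the number within the scatter. Set beside the same change on the first core, the comparison reads: the same change on two cores in this assay, an at least 1.4-fold lower number (0.17 log units; that floor lies within the scatter) from compound 2 to compound 1 and a 1.2-fold lower number (0.10 log units; within the scatter) from compound 3 to compound 4; the limit leaves it open whether they differ. Compound 2 gives only a limit and not a number, so the data do not show whether the change has the same size on both cores, and they neither establish nor rule out that its effect carries over from one core to the other: the limit of > 100000 nM in this assay, at which 1 of the 4 values shown sits.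

The compounds shown leave open whether a different group on this saturated chain carbon, such as a longer chain, a hydroxyl or an amine, would move the number beyond the scatter on either core. They also leave open how the change from methyl to ethyl would read on any further core in this series.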